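A Bromine Shifted on the Benzyl Group

A few compounds are considered here, and "the series" means these few. Any claim that something is new, unique, unknown or untested is made for them only; others in the source may bear on it.

For the measured compounds named here, compound 2 `O=C(CCCC1CCN(Cc2cccc(Br)c2)CC1)c1ncco1` gives 10 nM in an assay on isolated protein for inhibition of Fatty-acid amide hydrolase 1 (Homo sapiens) (a lower number here means a stronger inhibitor, a higher number a weaker inhibitor), the higher of the two numbers measured so far. Compound 1 `CC(C)OC(=O)N1CCC(CCCC(=O)c2ncco2)CC1` gives 4 nM in this assay. Going by the values given here, the one measured step, a 2.5-fold higher number from compound 1 to compound 2 (0.40 log units; beyond the scatter), concerns a different part of the molecule. Compound 3 `O=C(CCCC1CCN(Cc2ccc(Br)cc2)CC1)c1ncco1` differs from compound 2 by 4-bromophenyl in place of 3-bromophenyl on a saturated chain carbon bound to an amine nitrogen in a ring. Among the compounds with values here, no measured step bears on moving the bromine within the ring, so nothing points either way, and compound 3 is expected to stay within the scatter of compound 2, no change at the digits printed from compound 2 to compound 3 (within the scatter). The estimate for compound 3 is therefore 10 nM, with a range from 3 nM to 35 nM.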

Compound 3, half-maximal inhibitory concentration: 45 nM
Estimate against measurement, compound 3: 4.5-fold (0.65 log units) below; the measured number lies above the stated range.
By their numbers in this assay, from the lowest: compound 1; then compound 2; then compound 3.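

Swapping 3-bromobenzyl for 4-bromobenzyl gives a 4.5-fold higher number from compound 2 to compound 3 (0.65 log units; beyond the scatter) even though the atoms stay the same, so in this assay the place of the bromine on this benzyl group counts. Replacing isopropoxycarbonyl with 4-bromobenzyl gives an 11-fold higher number from compound 1 to compound 3 (1.05 log units; beyond the scatter) and so lands further from compound 1 than compound 2 does. No measurement here offers a reason for this difference.

Still open, on these data alone, is how a plain benzyl group, a 4-chlorobenzyl group or a 4-methoxybenzyl group would compare with these, and so whether bromine itself matters or only where a group sits.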